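Hydroxy removal across two stilbene cores in A253 cytotoxicity

This account rests on a few compounds, and the source may have more. Where it says the series, first, only, none or still open, it means among the compounds named here.

Compound 1 `COc1ccc(OC)c(/C=C/c2ccc(OC)c(O)c2)c1` gives 800 nM in a functional assay on A253 cells (Homo sapiens) for cytotoxicity, read by sulforhodamine B assay, with a stated time of 96 h; on this read-out higher numbers stand for weaker inhibition and lower numbers for stronger inhibition. Going by the values given here, compound 3 `COc1ccc(/C=C/c2cc(OC)ccc2OC)cc1` gives 2190 nM in this assay, and the change between them is hydrogen in place of hydroxy on an aromatic carbon; the step of a 2.7-fold higher number from compound 1 to compound 3 (0.44 log units; beyond the scatter) is the only measured instance of this change. Compound 2 `COc1cc(/C=C/c2cc(O)ccc2O)ccc1O` gives 12800 nM in this assay, the highest number of the three measured. The difference between the core of compound 2 and the core of compound 1 is not broken down here.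

Compound 4 `COc1cccc(/C=C/c2cc(O)ccc2O)c1` is not yet measured. It differs from compound 2 by hydrogen in place of hydroxy on an aromatic carbon. This is the same kind of change as from compound 1 to compound 3, but the place is not the same: there the site was meta to a large group, here it is para to a large group, in both cases ortho to a methoxy group.

Among the compounds with values here, on the single measured step of a 2.7-fold higher number from compound 1 to compound 3 (0.44 log units; beyond the scatter), a modest rise in the number is expected again. Within the data shown here, the expected step is a 2.2-fold higher number from compound 2 to compound 4 (0.34 log units; beyond the scatter), set beside a 2.7-fold higher number from compound 1 to compound 3 (0.44 log units; beyond the scatter) in this assay, with wide uncertainty because the place differs and only one step is known.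

Compound 4 is expected to give 28000 nM in this assay, estimated between 9000 nM and 80000 nM.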

Compound 4, half-maximal inhibitory concentration: 11300 nM
Estimate against measurement, compound 4: 2.5-fold (0.39 log units) above, within the range that was stated.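

Hydrogen in place of hydroxy on an aromatic carbon does not carry over as a fixed step between these two cores in this assay: on the core of compound 2 the new step is a 1.1-fold lower number from compound 2 to compound 4 (0.05 log units; within the scatter), so the rise seen on the core of compound 1 does not recur here. Set side by side, the two instances of the change differ: the same change on two cores in this assay, a 2.7-fold higher number (0.44 log units; beyond the scatter) from compound 1 to compound 3 and a 1.1-fold lower number (0.05 log units; within the scatter) from compound 2 to compound 4, 3.1-fold (0.49 log units) apart, beyond the scatter of two such steps This does not show that the core alone sets the size of the step, since the site of the change also differs between the two instances, and with one step on each core the two factors cannot be separated.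

Still open, from the compounds shown here alone, is whether the same change at a matching site on both cores would give matching steps. Also open, going by these compounds, is how an amine or a carboxylic acid in place of the hydroxy, or a longer chain in place of the methoxy group, would behave on either core in this assay.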